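The compounds below may be only part of what the source reports. "The series", "measured", "known", "first", "only" and "open" are said of these compounds alone.

In a functional assay on HCT-116 cells (Homo sapiens) for cytotoxicity, read by MTT assay, with a stated time of 72 h (on this read-out higher numbers stand for weaker inhibition and lower numbers for stronger inhibition), compound 1 (`N[C@H]1CC[C@H](Nc2c(C(=O)NCc3ccc(F)cc3)nc(N3CCCCS3(=O)=O)c3cccnc23)CC1`) gives > 10000 nM, which is a limit of the assay and not a number. In this assay, compound 2 (`C[C@@H](Nc1c(C(=O)NCc2ccc(F)cc2)nc(Br)c2cccnc12)c1ccccc1`) gives > 20000 nM, which is likewise a limit. Going by the values given here, compound 2 therefore has no exact position on the scale, and the only other value available offers no exact reference point. Among the compounds with values here, no step between measured compounds is available either.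

Compound 3 (`CN(C)CCCNc1c(C(=O)NCc2ccc(F)cc2)nc(Br)c2cccnc12`) has yet to be measured. It differs from compound 2 in a single place, on a nitrogen on an aromatic ring, where 3-(dimethylamino)propyl stands in place of 1-phenylethyl: 3-(dimethylamino)propyl in place of 1-phenylethyl on a nitrogen on an aromatic ring. The aromatic ring of carbon and the defined stereocentre of the departing group are lost, and the entering chain has no ring.

With only limits as a guide, the expectation is tentative: a moderate move towards stronger inhibition, beyond the usual scatter, though a further limit remains quite possible. The expected change is an at least 3.3-fold lower number from compound 2 to compound 3 (0.52 log units; beyond the scatter). For compound 3, the estimated value in this assay is 6000 nM, with an expected range of 1000 nM to 25000 nM.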

Compound 3, half-maximal inhibitory concentration: > 10000 nM
Compound 3 was reported as a limit; the forecaster's own chance of this, stated with the estimate: 40%; middle value at least 1.6-fold (0.22 log units) away from the limit.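

In this assay compound 3 gives > 10000 nM, which is a limit of the assay and not a number. Compound 2 also stands at a limit, so no step can be read between compound 2 and compound 3. The compounds shown leave open whether either group on that nitrogen gives stronger inhibition, and where any of the three compounds lies on the scale.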